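From a carboxy side chain to a methylsulfonyl one

The source may hold more compounds than are shown below. What is called first, only, known or untested is meant among the compounds shown, and "the series" means these compounds.

Compound 1 `CCOCc1nc(Nc2ccc(C(F)(F)F)cc2)c2ccc(-c3ncccc3C(F)(F)F)cc2n1` gives 0.6 ug/mL in a physicochemical assay for solubility, at pH 7.4; a higher number here means a more soluble compound, a lower number a less soluble compound
Compound 2 `CC(C)OCc1nc(Nc2ccc(C(F)(F)F)cc2)c2ccc(-c3ncccc3C(F)(F)F)cc2n1` gives 0.04 ug/mL in this assay
Compound 3 `O=C(O)COCc1nc(Nc2ccc(C(F)(F)F)cc2)c2ccc(-c3ncccc3C(F)(F)F)cc2n1` gives 125 ug/mL in this assay

Compound 3 has the highest number of the three, and by a wide margin. The next compound to be tested is compound 4 `CS(=O)(=O)CCc1nc(Nc2ccc(C(F)(F)F)cc2)c2ccc(-c3ncccc3C(F)(F)F)cc2n1` and its side chain differs from that of compound 3 as follows: (methylsulfonyl)methyl in place of carboxymethoxy on a saturated chain carbon bound to an aromatic carbon which means (methylsulfonyl)methyl in place of carboxymethoxy on a saturated chain carbon bound to an aromatic carbon. Cut one bond further out, the same difference reads (carboxymethoxy)methyl to 2-(methylsulfonyl)ethyl.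

The carboxy group leaves in this change, so two steps matter most. They are a 210-fold higher number from compound 1 to compound 3 (2.32 log units; beyond the scatter) and a 3100-fold higher number from compound 2 to compound 3 (3.49 log units; beyond the scatter) and both are large. Neither compound 1 nor compound 2 carries that group. A third step, a 15-fold lower number from compound 1 to compound 2 (1.18 log units; beyond the scatter) shows that numbers in this series can also move far without it, so the range must stay wide. Within the data shown here, no measured compound carries a methylsulfonyl group, so the data cannot place compound 4 directly. A large drop is therefore expected, and the estimate amounts to a 130-fold lower number from compound 3 to compound 4 (2.10 log units; beyond the scatter) in this assay as a rough figure. Compound 4 is estimated at 1 ug/mL with 0.1 ug/mL as the lower end and 10 ug/mL as the upper end of what is expected.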

Compound 4, solubility: 0.2 ug/mL
Estimate against measurement, compound 4: 5.0-fold (0.70 log units) above; low and high end bracket the measured number.
By their numbers in this assay, from the lowest: compound 2; then compound 4; then compound 1; then compound 3.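

In this assay, putting (methylsulfonyl)methyl in place of carboxymethoxy on the saturated chain carbon bound to an aromatic carbon gives a 630-fold lower number from compound 3 to compound 4 (2.80 log units; beyond the scatter), although the two groups have the same counts of heavy atoms and hydrogen-bond acceptors; matching those counts is therefore not enough to keep the high number of compound 3. What leaves in this change is the carboxy group with its hydrogen-bond donor, and no other compound shown has that group. Compound 4 instead sits among the other compounds without it, with a 5.0-fold higher number from compound 2 to compound 4 (0.70 log units; beyond the scatter) and a 3.0-fold lower number from compound 1 to compound 4 (0.48 log units; beyond the scatter), both modest steps beside the large drop from compound 3.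

The compounds shown leave open whether a different group on this chain, such as an amine, a primary amide or a carboxylic acid joined through an all-carbon chain with no ether oxygen, would bring the number back toward that of compound 3. No supporting measurement is available to explain why any of these numbers falls where it does.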